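The compounds below may be only part of what the source reports. "The series", "measured", "known", "first", "only" and "open" are said of these compounds alone.

Measured so far in a functional assay on A549 cells (Homo sapiens) for antiproliferative activity, read by MTT assay (on this read-out lower numbers stand for stronger inhibition and higher numbers for weaker inhibition), on this series:
Compound 1 (`O=C1N=C(N2CCC[C@H]2C(=O)Nc2ccc3ncnc(Nc4cccc(Cl)c4)c3c2)S/C1=C/c1ccc(Br)s1`) gives > 50000 nM as a limit.
Compound 2 (`COc1ccc(/C=C2/SC(N3CCC[C@H]3C(=O)Nc3ccc4ncnc(Nc5cccc(Cl)c5)c4c3)=NC2=O)cc1`) gives 31700 nM as a number.
Compound 3 (`O=C1N=C(N2CCC[C@H]2C(=O)Nc2ccc3ncnc(Nc4cccc(Cl)c4)c3c2)S/C1=C/c1ccccc1Cl`) gives > 50000 nM as a limit.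

Among the measured compounds shown here, compound 2 holds the only number of the three, and the other two values are limits (the limit of > 50000 nM in this assay, at which 2 of the 3 values shown sit). Compound 4 (`O=C1N=C(N2CCC[C@H]2C(=O)Nc2ccc3ncnc(Nc4cccc(Cl)c4)c3c2)S/C1=C/c1cccnc1`) is unmeasured. It has pyridin-3-yl in place of 4-methoxyphenyl on a double-bonded chain carbon bound to a double-bonded ring carbon. Two measured steps at this place bear on it (an at least 1.5-fold lower number from compound 1 to compound 2 (0.19 log units; that floor lies within the scatter)) and (an at least 1.5-fold higher number from compound 2 to compound 3 (0.19 log units; that floor lies within the scatter)), and both are floors within the scatter. Expected in this assay is no step beyond the scatter, with any drift towards a higher number (a 1.4-fold higher number from compound 2 to compound 4 (0.15 log units; within the scatter)). Compound 4 is estimated at 45000 nM with 20000 nM to 100000 nM as the expected range.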

Compound 4, half-maximal inhibitory concentration: 10400 nM
Estimate against measurement, compound 4: 4.3-fold (0.64 log units) above; measured number outside the range, below it.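

In this assay, the place on a double-bonded chain carbon bound to a double-bonded ring carbon now shows a change beyond the scatter, with pyridin-3-yl in place of 4-methoxyphenyl: a 3.0-fold lower number from compound 2 to compound 4 (0.48 log units; beyond the scatter). Pyridin-3-yl, the only group here with a hetero atom in a six-membered aromatic ring, also gives an at least 4.8-fold lower number from compound 3 to compound 4 (0.68 log units; beyond the scatter) and an at least 4.8-fold lower number from compound 1 to compound 4 (0.68 log units; beyond the scatter). Those two steps are floors, as the values of compound 1 and compound 3 are limits: the limit of > 50000 nM in this assay, at which 2 of the 4 values shown sit.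

Still open, going by these compounds, is whether pyridin-4-yl or pyridin-2-yl would match compound 4. Also open, on these data alone, is whether a ring carrying an amine or a carboxylic acid at this place would give a lower number.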